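The source may report more compounds than this note shows. Statements on the series, on what has been measured and on what is new or still open speak of the compounds shown alone.

Compound 3, with structure `COc1ccc(F)cc1CNCCCNc1ccnc2cc(-c3ccc(F)cc3)ccc12`, gives the lowest of the three numbers in an ADME assay on HepG2 cells (Homo sapiens) for cytotoxicity, read by luminescence, CellTiter-Glo and ATP content, with a stated time of 72 h (a lower number here means that less compound is needed, a higher number that more compound is needed for the effect), at 770 nM. Compound 1, with structure `COc1ccc(F)cc1CNCCCNc1ccnc2cc(Cc3cc(C)cc(C)c3)ccc12`, gives 940 nM in this assay, a difference that stays within the scatter, as a 1.2-fold lower number from compound 1 to compound 3 (0.09 log units; within the scatter) shows. Compound 2, with structure `COc1ccc(F)cc1CNCCCNc1ccnc2cc(Oc3ccc(C(C)(C)C)cc3)ccc12`, gives 7200 nM in this assay, and the step of a 9.4-fold lower number from compound 2 to compound 3 (0.97 log units; beyond the scatter) is the only one here that goes beyond the scatter.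

Compound 4, with structure `COc1ccc(F)cc1CNCCCNc1ccnc2cc(-c3ccc(C(F)(F)F)cc3)ccc12`, differs from compound 3 by trifluoromethyl in place of fluoro on an aromatic carbon on an aromatic carbon of a six-membered aromatic ring of carbon only. Within the data shown here, no measured step changes only that group; the nearest evidence is that exchanging the whole substituent on the shared core gave a 1.2-fold lower number from compound 1 to compound 3 (0.09 log units; within the scatter) and a 9.4-fold lower number from compound 2 to compound 3 (0.97 log units; beyond the scatter), and the two aryl-type compounds, compound 1 and compound 3, sit close together. The step of a 1.2-fold higher number from compound 3 to compound 4 (0.07 log units; within the scatter) in this assay is therefore expected to stay within the scatter. Compound 4 is estimated at 900 nM in this assay, with a range from 400 nM to 2200 nM.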

Compound 4, half-maximal effective concentration: 5190 nM
The estimate for compound 4 lay 5.8-fold (0.76 log units) below the measured number, and the stated range ends below it.
By their numbers in this assay, from the lowest: compounds 3 and 1 (each within the scatter of the next); then compounds 4 and 2 (each within the scatter of the next).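

In this assay, among these compounds, this position proved sensitive to a change in the substituent on the phenyl ring alone: with that ring kept, trifluoromethyl in place of fluoro gave a 6.7-fold higher number from compound 3 to compound 4 (0.83 log units; beyond the scatter), a step beyond the scatter and the first measured one to change only that group. An aryl group on this aromatic carbon therefore does not by itself keep a compound near compound 3, as the comparison with the benzyl compound gives a 5.5-fold higher number from compound 1 to compound 4 (0.74 log units; beyond the scatter), while the comparison with the phenoxy compound gives a 1.4-fold lower number from compound 2 to compound 4 (0.14 log units; within the scatter), which stays within the scatter. Nothing measured here accounts for this step.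

The compounds shown leave open whether chloro, methyl, methoxy or a nitrile at the same place would stay with compound 3 or fall with compound 4. They also leave open what an amine or a carboxylic acid there would give.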